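From Methylsulfanyl to a Larger Group in Compound 3

The compounds below may be only part of what the source reports. "The series", "measured", "known", "first", "only" and "open" are said of these compounds alone.

Of the compounds shown here, three have been tested in a functional assay on the whole organism for antagonist activity, with Mus musculus as the target; a higher number here means that more compound is needed for the effect, a lower number that less compound is needed. Compound 1 `Cn1c(-c2cccs2)nnc1S(C)(=O)=O` gives > 200 mg/kg, which is a limit of the assay. Compound 2 `Cn1nc(-c2cccc(F)c2)nc1S(C)(=O)=O` gives > 100 mg/kg, also a limit. On these data alone, compound 3 `CSc1nc(-c2ccccc2)n(C)n1` gives > 100 mg/kg, again a limit and not a number, so its true position remains open.

Compound 4 `Cn1nc([S+](C)[O-])nc1-c1ccccc1` differs from compound 3 in one place: a group of 3 heavy atoms (1 carbon, 1 oxygen, 1 sulfur; no ring) in place of a group of 2 heavy atoms (1 carbon, 1 sulfur; no ring), on an aromatic carbon. Methylsulfanyl leaves an aromatic carbon, between two ring nitrogen atoms, and a group of 3 heavy atoms enters there. For the measured compounds named here, no measured pair shows what such a change does, so the only guide is that compound 3 stands at > 100 mg/kg. The expected step, a step that the limit leaves unreadable from compound 3 to compound 4, is estimated to be no larger than the usual scatter, with no firm direction. For compound 4 the expected value is 120 mg/kg, with an estimated range from 40 mg/kg to 250 mg/kg. The assay may well report only a limit again.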

Compound 4, dose for half-maximal effect: > 200 mg/kg
Compound 4: a limit, no number; the forecaster's own chance of this, stated with the estimate: 60%; middle value at least 1.6-fold (0.22 log units) from the limit.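

Compound 3 and compound 4 each end at a limit of the assay and not at a number, so no step can be read between them. The compounds shown leave open what dose in this assay any of them would need for the effect.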